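Swapping a Chloroethyl Amide for a Chloropyridine Amide

The source may hold more compounds than are shown below. What is called first, only, known or untested is meant among the compounds shown, and "the series" means these compounds.

Measured in an ADME assay on Raji cells (Homo sapiens) for inhibition, with a stated time of 72 h; on this read-out lower numbers stand for an effect already at smaller amounts and higher numbers for an effect only at larger amounts of compound:
Compound 1, `C=CC(=O)Nc1cccc(-c2nc3ccccc3s2)c1`, gives > 25000 nM, which is a limit of the assay.
Compound 2, `O=C(CCl)Nc1cccc(-c2nc3ccccc3s2)c1`, gives 1700 nM.
Compound 3, `CC(Cl)C(=O)Nc1cccc(-c2nc3ccccc3s2)c1`, gives > 25000 nM, which is again a limit of the assay.

Compound 3 therefore sits at the limit of > 25000 nM in this assay, at which 2 of the 3 values shown sit; among the three, only compound 2 yields an actual number. The next compound, compound 4, `O=C(Nc1cccc(-c2nc3ccccc3s2)c1)c1cccnc1Cl`, differs from compound 3 in one place: 2-chloropyridin-3-yl in place of 1-chloroethyl on a carbonyl carbon. The measured steps that touch the same carbonyl carbon are an at least 14-fold lower number from compound 1 to compound 2 (1.16 log units; beyond the scatter) and an at least 14-fold higher number from compound 2 to compound 3 (1.16 log units; beyond the scatter), both large, while a step that the two limits leave unreadable from compound 1 to compound 3. Going by the values given here, none of the measured compounds carries an aromatic group on that carbonyl carbon, so the new group has no direct precedent here. Since only compound 2 departs from the limit, compound 4 is expected to stay near it, with an estimated 30000 nM and a range from 8000 nM to 100000 nM. The step this estimate implies is a step that the limit leaves unreadable from compound 3 to compound 4.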

Compound 4, half-maximal effective concentration: > 25000 nM
Compound 4 gave a limit, no number (the forecaster's own chance of this, stated with the estimate: 75%); the middle value lies beyond the limit too.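

Going by these compounds alone, an aromatic group now sits on the carbonyl carbon for the first time, and in this assay the 2-chloropyridin-3-yl group does not keep the effect seen with chloromethyl, giving an at least 14-fold higher number from compound 2 to compound 4 (1.16 log units; beyond the scatter). The steps to compound 4 from compound 1 and from compound 3 cannot be read, with limits at both ends. Chloromethyl thus remains the only group at this position that gives an actual number, and a chlorine atom in the group is not enough on its own, as compound 3 and compound 4 also carry one: the limit of > 25000 nM in this assay, at which 3 of the 4 values shown sit.

From the compounds shown here alone, how far compound 1, compound 3 and compound 4 lie from one another stays unknown, since none of them has a number. Also open, going by these compounds, is whether bromomethyl or a plain phenyl ring on the same carbonyl carbon would give a measurable value.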